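The source may report more compounds than this note shows. Statements on the series, on what has been measured and on what is new or still open speak of the compounds shown alone.

Compound 1 `Cc1ccc(Nc2nc(SCc3cn(CC(=O)NC(=O)Nc4ccccn4)nn3)nc(-c3ccc(C(C)C)cc3)c2C#N)cc1`: 6700 nM
Compound 2 `CC(C)c1ccc(Nc2nc(SCc3cn(CC(=O)NC(=O)Nc4ccccn4)nn3)nc(-c3ccc(C(C)C)cc3)c2C#N)cc1`: 2490 nM
Compound 3 `COc1cc(-c2nc(SCc3cn(CC(=O)NC(=O)Nc4ccccn4)nn3)nc(Nc3ccc(C(C)C)cc3)c2C#N)cc(OC)c1OC`: > 64000 nM

In a functional assay on ECa-109 cells (Homo sapiens) for inhibition, read by MTT assay, with a stated time of 72 h (on this read-out lower numbers stand for stronger inhibition and higher numbers for weaker inhibition), compound 3 gives no number but only a limit of the assay, > 64000 nM. It is the compound that sits at the limit of > 64000 nM in this assay, at which 1 of the 3 values shown sits. Compound 4 `COc1cc(-c2nc(SCc3cn(CC(=O)NC(=O)Nc4ccccn4)nn3)nc(Nc3ccc(C)cc3)c2C#N)cc(OC)c1OC` differs from compound 3 by methyl in place of isopropyl on an aromatic carbon. Among the compounds with values here, one measured step bears on this change, and it runs the other way: a 2.7-fold lower number from compound 1 to compound 2 (0.43 log units; beyond the scatter). Read in reverse, that step points to a modest higher number in this assay for compound 4. Since compound 3 already returns only a limit, compound 4 is expected to return a limit as well, estimated at 120000 nM with a range of 40000 nM to 400000 nM. This expectation amounts to a step that the limit leaves unreadable from compound 3 to compound 4.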

Compound 4, half-maximal inhibitory concentration: 21300 nM
The estimate for compound 4 lay 5.6-fold (0.75 log units) above the measured number, outside the stated range (below it).
By their numbers in this assay, from the lowest: compound 2; then compound 1; then compound 4. At a limit, above all of these: compound 3.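

In this assay, methyl in place of isopropyl gives an at least 3.0-fold lower number from compound 3 to compound 4 (0.47 log units; beyond the scatter), so the direction of this change at this position differs with the group elsewhere on the core: the same change on two cores in this assay, a 2.7-fold lower number (0.43 log units; beyond the scatter) from compound 1 to compound 2 and an at least 3.0-fold higher number (0.47 log units; beyond the scatter) from compound 4 to compound 3, at least 8.0-fold (0.90 log units) apart, beyond the scatter of two such steps

The 3,4,5-trimethoxyphenyl exchange likewise changes the number less when methyl occupies this position, with a 3.2-fold higher number from compound 1 to compound 4 (0.50 log units; beyond the scatter): the same change on two cores in this assay, an at least 25-fold higher number (1.40 log units; beyond the scatter) from compound 2 to compound 3 and a 3.2-fold higher number (0.50 log units; beyond the scatter) from compound 1 to compound 4, at least 8.0-fold (0.90 log units) apart, beyond the scatter of two such steps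

Going by these compounds, whether a methoxy group or a chlorine atom at this position would follow compound 4 or compound 2 stays open. So does whether an unsubstituted phenyl would behave the same way on either core.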